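A few compounds are considered here, and "the series" means these few. Any claim that something is new, unique, unknown or untested is made for them only; others in the source may bear on it.

Measured so far:
compound 1, `O=Cc1ccc(-c2cn3ccnc3c(-c3ccc4ncn(C5CCCCC5)c4c3)n2)cc1` — 0.53%
compound 2, `c1cn2cc(-c3ccsc3)nc(-c3ccc4ncn(C5CCCCC5)c4c3)c2n1` — 6.34%

Both numbers come from a functional assay on NCI-H226 cells (Homo sapiens) for inhibition, read by sulforhodamine B assay, with a stated time of 48 h, tested at 10 uM; on this read-out lower numbers stand for less inhibition and higher numbers for more inhibition at the one concentration tested (going by the name of the read-out). Compound 2 holds the higher of the two numbers, but its nearest neighbour, compound 1, sits only a number 5.8 percentage points higher from compound 1 to compound 2 (within the scatter), so on this pair nothing separates the two beyond the usual scatter.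

Compound 3, `Brc1ccc(-c2cn3ccnc3c(-c3ccc4ncn(C5CCCCC5)c4c3)n2)cc1`, has not been measured. It differs from compound 2 in one place: 4-bromophenyl in place of thiophen-3-yl on an aromatic carbon. Within the data shown here, the one measured step that bears on this is the exchange at the same aromatic carbon from compound 1 to compound 2, which changed this assay by a number 5.8 percentage points higher from compound 1 to compound 2 (within the scatter) and stayed within the scatter. That single step gives no sign that the group at this carbon moves the read-out, so compound 3 is expected to land within the scatter of compound 2, a step of a number 1.3 percentage points lower from compound 2 to compound 3 (within the scatter) in this assay. Compound 3 is therefore estimated at 5%, between -6% and 16%.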

Compound 3, a percentage reported as inhibition, at one concentration (the size of the read-out at that concentration, not a potency): 23.3%
Estimate against measurement, compound 3: 18.3 percentage points below; the whole stated range lies below it.
By their numbers in this assay, from the lowest: compounds 1 and 2 (each within the scatter of the next); then compound 3.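

In this assay the group on this aromatic carbon does move the read-out: 4-bromophenyl in place of thiophen-3-yl gives a number 17 percentage points higher from compound 2 to compound 3 (beyond the scatter) and bromo in place of formyl gives a number 22.8 percentage points higher from compound 1 to compound 3 (beyond the scatter), which the earlier exchange had not shown. Compound 1 and compound 3 share the phenyl ring, so changing its substituent alone is enough for a step beyond the scatter, whereas the step to compound 3 from the thiophene of compound 2 changes the ring and brings in bromine together. Nothing available explains why the bromo compound stands apart.

The compounds shown leave open whether bromine itself matters or whether a chloro, methoxy or amino group on the phenyl ring would serve as well. They also do not show whether an unsubstituted phenyl already reaches the level of compound 3.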